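Anilino series in the maximal electroshock model: compound 4

This account rests on a few compounds, and the source may have more. Where it says the series, first, only, none or still open, it means among the compounds named here.

Measured compounds:
compound 1 `Cc1ccccc1Nc1nnc(Nc2nc(-c3ccc([N+](=O)[O-])cc3)cs2)s1` gives 100 mg/kg in a functional assay on the whole organism (strain albino) with Mus musculus as the target, in the maximal electroshock model, with a stated time of 0.5 h; a higher number here means that more compound is needed for the effect, a lower number that less compound is needed
compound 2 `Cc1ccc(Nc2nnc(Nc3nc(-c4ccc([N+](=O)[O-])cc4)cs3)s2)cc1` gives 30 mg/kg in this assay
compound 3 `COc1ccccc1Nc1nnc(Nc2nc(-c3ccc([N+](=O)[O-])cc3)cs2)s1` gives 300 mg/kg in this assay

Compound 3 holds the highest number of the three; compound 1 is nearest to it, with a 3.0-fold higher number from compound 1 to compound 3 (0.48 log units; beyond the scatter) separating them, and compound 2 is furthest, with a 10-fold higher number from compound 2 to compound 3 (1.00 log units; beyond the scatter) separating them. Both of those steps lie beyond the scatter, so compound 3 needs the most compound of the set.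

Compound 4 `COc1ccc(Nc2nnc(Nc3nc(-c4ccc([N+](=O)[O-])cc4)cs3)s2)cc1` has not yet been measured in this assay. It differs from compound 3 by 4-methoxyphenyl in place of 2-methoxyphenyl on a nitrogen on an aromatic ring. Among the measured compounds shown here, the one measured step of the same kind is a 3.3-fold lower number from compound 1 to compound 2 (0.52 log units; beyond the scatter), where the methyl group moved in the same way on the same nitrogen and the number fell by a modest amount beyond the scatter. Nothing in the series shows that a methoxy group would behave differently from a methyl group under that move, so the expectation is a fall of similar size.

Compound 4 is therefore expected to give about 100 mg/kg in this assay, with a range from 30 mg/kg to 300 mg/kg. That estimate means a step of a 3.0-fold lower number from compound 3 to compound 4 (0.48 log units; beyond the scatter), expected to lie beyond the scatter.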

Compound 4, minimum effective dose: 30 mg/kg
Estimate against measurement, compound 4: 3.3-fold (0.52 log units) above, within the range that was stated.
By their numbers in this assay, from the lowest: compounds 2 and 4 (each within the scatter of the next); then compound 1; then compound 3.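

In this assay, the move from 2-methoxyphenyl to 4-methoxyphenyl on the nitrogen gives a 10-fold lower number from compound 3 to compound 4 (1.00 log units; beyond the scatter), so the lower number seen for the methyl pair, a 3.3-fold lower number from compound 1 to compound 2 (0.52 log units; beyond the scatter), also appears with methoxy. With the group in the 4-substituted form, the choice between methyl and methoxy gives no change at the digits printed from compound 2 to compound 4 (within the scatter), while the comparison across both changes gives a 3.3-fold lower number from compound 1 to compound 4 (0.52 log units; beyond the scatter), which places 4-methoxyphenyl on the lower side of 2-methylphenyl as well. The earlier compounds showed the methoxy-for-methyl change only in the 2-substituted form, and the series now shows that its outcome differs with the place of the group: the same change on two cores in this assay, a 3.0-fold higher number (0.48 log units; beyond the scatter) from compound 1 to compound 3 and no change at the digits printed (within the scatter) from compound 2 to compound 4, 3.0-fold (0.48 log units) apart, beyond the scatter of two such steps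

From the compounds shown here alone, whether the same pattern holds for other groups on this aromatic ring, such as chlorine, a dimethylamino group or a carboxylic acid, remains open. Also open, going by these compounds, is how plain phenyl on that nitrogen compares with compound 2 and compound 4, and so whether either group is needed at all.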